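The compounds below may be only part of what the source reports. "The series", "measured", "known", "first", "only" and "open" are said of these compounds alone.

Working notes on the series. Compound 1 `CC(C)CNc1nc(N)nc2c1ncn2/C=C1/CC1(CO)CO` carries isobutylamino on the shared core; in an ADME assay on MOLT-3 cells (Homo sapiens) for cytotoxicity, with a stated time of 7 days (a lower number here means that less compound is tolerated, a higher number that more compound is tolerated), compound 1 gives "not determined" (no result reported), so compound 1 has no single number here. Compound 2 `CCCOc1nc(N)nc2c1ncn2/C=C1/CC1(CO)CO` carries propoxy on the aromatic carbon. In this assay compound 2 gives > 20000 nM, which is a limit of the assay and not a number. Compound 3 `CCCCNc1nc(N)nc2c1ncn2/C=C1/CC1(CO)CO` carries butylamino on the same aromatic carbon. In this assay compound 3 gives > 20000 nM, also a limit. The step that the two limits leave unreadable from compound 2 to compound 3 therefore has no readable size. Compound 4 `CNc1nc(N)nc2c1ncn2/C=C1/CC1(CO)CO` is compound 1 with hydrogen in place of isopropyl on a saturated chain carbon bound to a nitrogen on an aromatic ring. Within the data shown here, no measured step bears on this change: the only comparison in the set gives no size, and the limit of > 20000 nM in this assay, at which 2 of the 3 values shown sit, is where most of the set sits. No step beyond the scatter is therefore expected, in either direction, and another limit is the likely outcome. Compound 4 is estimated at 20000 nM in this assay, with a range of 10000 nM to 40000 nM.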

Compound 4, half-maximal cytotoxic concentration: > 20000 nM
Compound 4 was reported as a limit; the forecaster's own chance of this, stated with the estimate: 80%; the middle value sits exactly at the limit.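

In this assay compound 4 gives > 20000 nM, a limit and not a number. Among these compounds, no step among compound 2, compound 3 and compound 4 can be read. The compounds shown leave open how these three compare with one another, and most of the set sits at one limit: the limit of > 20000 nM in this assay, at which 3 of the 4 values shown sit.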